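Adding an Ethyl Group to Compound 3

The compounds below may be only part of what the source reports. "The series", "measured", "known", "first", "only" and "open" are said of these compounds alone.

Compound 3 `CC(C)(C)n1ncc(OCc2nnc(-c3ccccc3)o2)c(Cl)c1=O` gives 12200 nM in a functional assay on the whole organism for inhibition, with Mythimna separata as the target, with a stated time of 5 days (a higher number here means that more compound is needed for the effect, a lower number that less compound is needed), the lowest of the numbers shown. Compound 1 `CC(C)(C)n1ncc(OCc2nnc(-c3ccccc3Cl)o2)c(Cl)c1=O` gives 61200 nM, and the difference is a 5.0-fold lower number from compound 1 to compound 3 (0.70 log units; beyond the scatter). For compound 2 `CC(C)(C)n1ncc(OCc2nnc(-c3cccs3)o2)c(Cl)c1=O` this assay reports only a limit, > 299000 nM. The remaining steps, an at least 4.8-fold higher number from compound 1 to compound 2 (0.68 log units; beyond the scatter) and an at least 24-fold lower number from compound 2 to compound 3 (1.38 log units; beyond the scatter), change the aromatic group itself. Compound 4 `CCc1ccc(-c2nnc(COc3cnn(C(C)(C)C)c(=O)c3Cl)o2)cc1` differs from compound 3 by ethyl in place of hydrogen on an aromatic carbon. For the measured compounds named here, no measured step adds an alkyl group to this ring, so the measured steps give little direction for this change. Compound 4 is therefore estimated to give about 10000 nM, within 3000 nM to 40000 nM. The expected step is a 1.2-fold lower number from compound 3 to compound 4 (0.09 log units; within the scatter), within the scatter.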

Compound 4, half-maximal effective concentration: 14500 nM
Compound 4: middle estimate off by 1.5-fold (0.16 log units), on the low side; the measured number falls inside the stated range.
By their numbers in this assay, from the lowest: compounds 3 and 4 (each within the scatter of the next); then compound 1. At a limit, above all of these: compound 2.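

In this assay, ethyl on an aromatic carbon para to a large group leaves the number within the scatter: a 1.2-fold higher number from compound 3 to compound 4 (0.08 log units; within the scatter). So 4-ethylphenyl stands with phenyl here, and it keeps a clear margin over 2-chlorophenyl, with a 4.2-fold lower number from compound 1 to compound 4 (0.63 log units; beyond the scatter). The step of an at least 20-fold lower number from compound 2 to compound 4 (1.31 log units; beyond the scatter) rests on a limit, that of compound 2: the limit of > 299000 nM in this assay, at which 1 of the 4 values shown sits.

A single ethyl group gives no trend for this carbon. On these data alone, whether a longer chain, an amine or a carboxylic acid in the same place would also leave the number unchanged stays open.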